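A few compounds are considered here, and "the series" means these few. Any claim that something is new, unique, unknown or untested is made for them only; others in the source may bear on it.

Measured so far:
Compound 1 `c1coc(-c2ccccc2NCC2=NCCN2)c1`: 0.468 nM
Compound 2 `Cc1ncc(-c2ccccc2NCC2=NCCN2)o1`: 110 nM
Compound 3 `c1ccc(-c2cnoc2)c(NCC2=NCCN2)c1`: 45.7 nM

In a functional assay for activation of Alpha-1A adrenergic receptor (Homo sapiens), read by calcium flux (on this read-out lower numbers stand for an effect already at smaller amounts and higher numbers for an effect only at larger amounts of compound), compound 3 gives 45.7 nM, the second highest of these three numbers. Its nearest neighbour is compound 2 with 110 nM, while compound 1 with 0.468 nM lies far lower. Compound 4 `Cc1nc(-c2ccccc2NCC2=NCCN2)no1` differs from compound 3 by the change (5-methyl-1,2,4-oxadiazol-3-yl in place of 1,2-oxazol-4-yl on an aromatic carbon). Within the data shown here, three measured steps bear on this: a 98-fold higher number from compound 1 to compound 3 (1.99 log units; beyond the scatter), a 240-fold higher number from compound 1 to compound 2 (2.37 log units; beyond the scatter) and a 2.4-fold lower number from compound 2 to compound 3 (0.38 log units; beyond the scatter). Both swaps away from furan-2-yl gave greatly higher numbers, and the methyl-bearing ring of compound 2 gave a modestly higher number than the ring of compound 3. Since the entering ring again carries a methyl, a modestly higher number is expected, the expected step being a 2.6-fold higher number from compound 3 to compound 4 (0.42 log units; beyond the scatter). Compound 4 is therefore estimated at 120 nM, within 30 nM to 500 nM.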

Compound 4, half-maximal effective concentration: 724 nM
For compound 4 the middle estimate is 6.0-fold (0.78 log units) below the measured one; measured number above the stated range.
By their numbers in this assay, from the lowest: compound 1; then compound 3; then compound 2; then compound 4.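

In this assay, the 5-methyl-1,2,4-oxadiazol-3-yl group gives the highest number of the four compounds, with a 16-fold higher number from compound 3 to compound 4 (1.20 log units; beyond the scatter) and a 1500-fold higher number from compound 1 to compound 4 (3.19 log units; beyond the scatter). Two rings that both carry a methyl still differ, with a 6.6-fold higher number from compound 2 to compound 4 (0.82 log units; beyond the scatter), so the methyl alone does not set the number at this position. Nothing measured here explains what drives these steps. On these data alone, what an amine or a carboxylic acid on this aromatic carbon would give stays open. The contribution of the methyl also stays open, since no two compounds shown differ by that methyl alone.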